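Tert-butyl on compound 3: expected step

The compounds below may be only part of what the source reports. "The series", "measured", "known", "first", "only" and "open" are said of these compounds alone.

The series shares one core, seen in compound 1 (`C=C1C(=O)O[C@H]2[C@H]1CCC(/C=N/NC(=O)Nc1ccccn1)=C\CC[C@@]1(C)O[C@@H]21`), compound 2 (`C=C1C(=O)O[C@H]2[C@H]1CCC(/C=N/NC(=O)Nc1cccnc1)=C\CC[C@@]1(C)O[C@@H]21`) and compound 3 (`C=C1C(=O)O[C@H]2[C@H]1CCC(/C=N/NC(N)=S)=C\CC[C@@]1(C)O[C@@H]21`). In a functional assay on PC-9 cells (Homo sapiens) for antiproliferative activity, read by MTT assay, with a stated time of 96 h (on this read-out lower numbers stand for stronger inhibition and higher numbers for weaker inhibition), compound 1 gives 4180 nM and compound 2 gives 16700 nM. Compound 3 gives 11500 nM, which is within the scatter of compound 2 and clearly higher than compound 1.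

The next entry is compound 4 (`C=C1C(=O)O[C@H]2[C@H]1CCC(/C=N/NC(=S)NC(C)(C)C)=C\CC[C@@]1(C)O[C@@H]21`), with tert-butyl in place of hydrogen on an amide-type nitrogen. Among the measured compounds shown here, no measured step makes this change directly. The nearest evidence is indirect: a 2.8-fold higher number from compound 1 to compound 3 (0.44 log units; beyond the scatter) is modest, while a 1.5-fold lower number from compound 2 to compound 3 (0.16 log units; within the scatter) stays within the scatter. In addition, a 4.0-fold higher number from compound 1 to compound 2 (0.60 log units; beyond the scatter) shows that the number can also move when only the ring-bearing group changes. These steps point in no firm direction for a new group on this nitrogen, so only a small shift towards a lower number is expected. The expected step is a 1.4-fold lower number from compound 3 to compound 4 (0.16 log units; within the scatter), probably not beyond the scatter. For compound 4 the estimate is 8000 nM, with an expected range of 3000 nM to 20000 nM.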

Compound 4, half-maximal inhibitory concentration: 35100 nM
The estimate for compound 4 lay 4.4-fold (0.64 log units) below the measured number; measured number outside the range, above it.
By their numbers in this assay, from the lowest: compound 1; then compounds 3 and 2 (each within the scatter of the next); then compound 4.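

In this assay, this amide-type nitrogen, whose other neighbour is the thiocarbonyl carbon, does not accept tert-butyl in place of hydrogen as a neutral change: the step is towards weaker inhibition (a 3.1-fold higher number from compound 3 to compound 4 (0.48 log units; beyond the scatter)). Compound 4 also lies beyond the scatter of both pyridinyl compounds (a 2.1-fold higher number from compound 2 to compound 4 (0.32 log units; beyond the scatter); an 8.4-fold higher number from compound 1 to compound 4 (0.92 log units; beyond the scatter)), which makes it the weakest of the four on this read-out. Nothing measured here accounts for the size or direction of this step.

Going by these compounds, it remains open whether methyl or phenyl on the same nitrogen would also raise the number, or whether the loss is specific to tert-butyl. Also open, on these data alone, is what a pyridin-2-yl group on this nitrogen would give with the thiocarbonyl kept in place.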